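The Same Aryl Change Tried on a Second Core

The source may hold more compounds than are shown below. What is called first, only, known or untested is meant among the compounds shown, and "the series" means these compounds.

Measured compounds:
Compound 1, `COc1cccc(N2CCN(CCCn3nc(-c4ccccc4)c(C#N)c3C)CC2)c1`: 21%
Compound 2, `Cc1ccc(N2CCN(CCCn3nc(-c4ccccc4)c(C#N)c3C)CC2)cc1`: 8%
Compound 3, `COc1cccc(N2CCN(CCCn3cccc3C(C)=O)CC2)c1`: 26%

All three were tested in a functional assay on the whole organism (Abdomen, strain Swiss) for inhibition, with Mus musculus as the target, with stated times of 30 min, 10 min and 5 min, at a dose of 20 mg/kg by the oral route; a higher number here means a stronger effect of the compound at the dose given, a lower number a weaker effect. Compound 1 and compound 2 share one core and differ only in 4-methylphenyl in place of 3-methoxyphenyl on an amine nitrogen in a ring; that change gave a number 13 percentage points lower from compound 1 to compound 2 (beyond the scatter). Compound 3 carries a different core; how the core of compound 3 differs from the core of compound 1 is not broken down here. Compound 3 and compound 1 give values within the scatter of each other, so no order between them can be read.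

Compound 4, `CC(=O)c1cccn1CCCN1CCN(c2ccc(C)cc2)CC1`, is not yet measured. It is made from compound 3 by 4-methylphenyl in place of 3-methoxyphenyl on an amine nitrogen in a ring, the same kind of change seen from compound 1 to compound 2, at a place described in the same words. Because the measured step of a number 13 percentage points lower from compound 1 to compound 2 (beyond the scatter) lowered the read-out on the first core, a drop of similar size is expected on the second core, giving an estimated step of a number 13 percentage points lower from compound 3 to compound 4 (beyond the scatter). Compound 4 is therefore estimated at 13%, most likely between 0% and 26%.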

Compound 4, a percentage reported as inhibition, in the whole organism at one dose (the size of the read-out at that dose, not a potency): 7%
For compound 4 the middle estimate is 6 percentage points above the measured one; low and high end bracket the measured number.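

On the second core, 4-methylphenyl in place of 3-methoxyphenyl gave a number 19 percentage points lower from compound 3 to compound 4 (beyond the scatter) in this assay, so the read-out fell here as it had on the first core. Set side by side, the two steps point the same way and their sizes cannot be told apart: the same change on two cores in this assay, a number 13 percentage points lower (beyond the scatter) from compound 1 to compound 2 and a number 19 percentage points lower (beyond the scatter) from compound 3 to compound 4, 6 percentage points apart, within the scatter of two such steps. Going by these compounds alone, this suggests that the change carries over between these two cores in this test, but it rests on only two pairs at a single oral dose, so it does not show that the drop would hold on other cores, and it does not explain why the read-out falls.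

Within the data shown here, only two aryl groups on the amine nitrogen appear here, so it remains open how an unsubstituted phenyl or a chlorophenyl group would read on either core. Also open, as far as these compounds go, are how a longer chain leading to the core would affect the result, and whether the drop persists at other doses.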